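Halogen swap on the sulfonamide aryl ring: bromo to fluoro

The source may hold more compounds than are shown below. What is called first, only, known or untested is meant among the compounds shown, and "the series" means these compounds.

Measured compounds:
Compound 1, `O=S(=O)(NCCCNc1nccc(-c2[nH]c(-c3ccccc3)nc2-c2ccc(F)c(O)c2)n1)c1ccc(Cl)cc1`, 14200 nM
Compound 2, `O=S(=O)(NCCCNc1nccc(-c2[nH]c(-c3ccccc3)nc2-c2ccc(F)c(O)c2)n1)c1ccc(Br)cc1`, 5660 nM

In a functional assay on LOX IMVI cells (Homo sapiens) for cytotoxicity, read by MTT assay, with a stated time of 24 h (a lower number here means a stronger inhibitor, a higher number a weaker inhibitor), compound 2 gives the lowest of the two numbers recorded so far; its nearest neighbour is compound 1, which differs from it only in the halogen on the sulfonyl-bearing ring. For the measured compounds named here, that one step, a 2.5-fold lower number from compound 1 to compound 2 (0.40 log units; beyond the scatter), is the only measured change that bears on the question at hand.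

Compound 3, `O=S(=O)(NCCCNc1nccc(-c2[nH]c(-c3ccccc3)nc2-c2ccc(F)c(O)c2)n1)c1ccc(F)cc1`, has not yet been measured. Its difference from compound 2 is fluoro in place of bromo on an aromatic carbon. Going by the values given here, the single measured step runs from chloro to bromo and lowers the number; the move to fluoro runs in the opposite direction from bromo, past chloro, so the expectation is a higher number than compound 2 shows, rather than a lower one, and by an amount at least as large as the measured step.

Compound 3 is therefore expected to give 25000 nM in this assay, within a range from 10000 nM to 60000 nM, which corresponds to an estimated step of a 4.4-fold higher number from compound 2 to compound 3 (0.65 log units; beyond the scatter).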

Compound 3, half-maximal inhibitory concentration: 19200 nM
Compound 3: the middle estimate sits 1.3-fold (0.11 log units) above what was measured, and the stated range covers the measured number.
By their numbers in this assay, from the lowest: compound 2; then compounds 1 and 3 (each within the scatter of the next).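

In this assay, the change on the 4-bromophenyl ring gives a 3.4-fold higher number from compound 2 to compound 3 (0.53 log units; beyond the scatter), so the lower number seen with bromo at this position does not extend to fluoro. The second new step, a 1.4-fold higher number from compound 1 to compound 3 (0.13 log units; within the scatter), lies within the scatter, which means that fluoro and chloro cannot be told apart here, and the three halogens do not form a graded series across the listed compounds: bromo alone stands apart from the other two, something the single step from chloro to bromo could not show. Nothing available explains why bromo differs from the other two halogens at this position on the aromatic ring.

These compounds leave open whether the lower number is particular to bromo or would also appear with iodo, or with a non-halogen group such as methyl, methoxy or trifluoromethyl in the same place, and how an unsubstituted phenyl would compare. They also leave open whether the gap between bromo and the other two halogens would persist with a longer chain between the sulfonamide nitrogen and the shared core.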